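Fluoro to methoxy: expected effect on cell viability

The compounds below may be only part of what the source reports. "The series", "measured", "known", "first", "only" and "open" are said of these compounds alone.

Measured so far:
compound 1, `Fc1ccc(-c2cc(-c3ccc4cc(F)ccc4n3)nn2-c2ccccc2)cc1`, gives 89.7% in an ADME assay on Huh-7 cells (Homo sapiens) for cytotoxicity, read by XTT assay, with a stated time of 3 days, tested at 200 uM; on this read-out lower numbers stand for a stronger effect and higher numbers for a weaker effect at the one concentration tested
compound 2, `Fc1ccc2nc(-c3cc(-c4ccccc4)nn3-c3ccccc3)ccc2c1`, gives 98.3% in this assay
compound 3, `Fc1ccc(-c2cc(-c3ccc4cc(F)ccc4n3)n(-c3ccccc3)n2)cc1`, gives 87.5% in this assay

Compound 3 sits within the scatter of compound 1 and is set apart only from compound 2, by a number 10.8 percentage points lower from compound 2 to compound 3 (beyond the scatter). Compound 4, `COc1ccc(-c2cc(-c3ccc4cc(F)ccc4n3)n(-c3ccccc3)n2)cc1`, differs from compound 3 by methoxy in place of fluoro on an aromatic carbon. Among the measured compounds shown here, no measured step swaps methoxy for fluoro; the single measured step, a number 10.8 percentage points lower from compound 2 to compound 3 (beyond the scatter), concerns a different change and is modest. In this assay no step beyond the scatter is therefore expected, so the estimated step is a number 0.5 percentage points higher from compound 3 to compound 4 (within the scatter). Compound 4 is expected to give 88%, between 75% and 100%.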

Compound 4, a percentage reported as activity, at one concentration (the size of the read-out at that concentration, not a potency): 98.9%
The estimate for compound 4 lay 10.9 percentage points below the measured number, within the range that was stated.
By their numbers in this assay, from the lowest: compounds 3, 1, 2 and 4 (each within the scatter of the next, the first and the last beyond it).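

On the 4-fluorophenyl ring of compound 3, the group at this place does matter in this assay: going from 4-fluorophenyl to 4-methoxyphenyl gives a number 11.4 percentage points higher from compound 3 to compound 4 (beyond the scatter). Methoxy and hydrogen at this same place cannot be told apart, with a number 0.6 percentage points higher from compound 2 to compound 4 (within the scatter), so among these three groups only fluoro stands apart from the other two. Nothing available here accounts for this difference. On these data alone, whether an amine, a carboxylic acid or a longer chain such as ethoxy at this place would group with fluoro or with methoxy and hydrogen remains open.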